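The source may hold more compounds than are shown below. What is called first, only, known or untested is meant among the compounds shown, and "the series" means these compounds.

Measured so far:
compound 1 `COc1ccc(S(=O)(=O)Nc2cccc(I)c2)cc1N1CCNCC1` — 0.501 nM
compound 2 `COc1ccc(S(=O)(=O)Nc2c(F)cc(Br)cc2F)cc1N1CCNCC1` — 158 nM

Compound 2 stands at the higher of the two numbers in an assay on isolated protein for binding affinity to 5-hydroxytryptamine receptor 6 (Homo sapiens); a lower number here means a stronger inhibitor, a higher number a weaker inhibitor; its nearest neighbour is compound 1, and the step of a 320-fold higher number from compound 1 to compound 2 (2.50 log units; beyond the scatter) is the only one measured so far. Compound 3 `COc1ccc(S(=O)(=O)Nc2cc(Cl)c(Cl)cc2Cl)cc1N1CCNCC1` is not yet measured. It differs from compound 2 by 2,4,5-trichlorophenyl in place of 4-bromo-2,6-difluorophenyl on a sulfonamide nitrogen. Going by the values given here, the one step that bears on this change is a 320-fold higher number from compound 1 to compound 2 (2.50 log units; beyond the scatter), which shows that the pattern of halogens on the phenyl ring on the sulfonamide nitrogen can move the number a great deal in this assay. Compound 3 carries three chlorines in place of one bromine and two fluorines, so the new arrangement is not covered by either measured compound; a step back toward compound 1 seems plausible but uncertain. For compound 3 the expected step is a 7.9-fold lower number from compound 2 to compound 3 (0.90 log units; beyond the scatter). The estimate for compound 3 is 20 nM, with a range from 3 nM to 150 nM.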

Compound 3, inhibition constant: 5.01 nM
The estimate for compound 3 lay 4.0-fold (0.60 log units) above the measured number; measured number inside the range.
By their numbers in this assay, from the lowest: compound 1; then compound 3; then compound 2.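

In this assay, 2,4,5-trichlorophenyl on the sulfonamide nitrogen gives a much lower number than 4-bromo-2,6-difluorophenyl (a 32-fold lower number from compound 2 to compound 3 (1.50 log units; beyond the scatter)), so a phenyl ring carrying three halogens is not in itself tied to a high number here. It still falls short of 3-iodophenyl (a 10-fold higher number from compound 1 to compound 3 (1.00 log units; beyond the scatter)), which shows that the number at this position depends on which halogens the ring carries and how they are arranged, not simply on their presence. No measurement is available that explains either step.

The compounds shown leave open whether any single chlorine of the 2,4,5-trichlorophenyl group accounts for the step and whether halogen is needed on this ring at all. Also open, from the compounds shown here alone, is how an unsubstituted phenyl, or a phenyl bearing a nitrile or a carboxylic acid, would compare with these numbers.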